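Swapping the aryl group on the anilino nitrogen of compound 2

The source may report more compounds than this note shows. Statements on the series, on what has been measured and on what is new or still open speak of the compounds shown alone.

Measured so far:
- compound 1, `COc1cc(NC(=O)Nc2cc(Nc3cc(Br)ccc3OC)ncn2)cc(OC)c1`, 82.5%
- compound 2, `CCc1ccc(Nc2cc(NC(=O)Nc3c(Cl)cccc3Cl)ncn2)cc1`, 70.1%
- compound 3, `COc1cc(Nc2cc(NC(=O)Nc3c(Cl)cccc3Cl)ncn2)cc(OC)c1`, 90%

Of the compounds shown here, three share a core and have been tested in a functional assay on PC-9 cells (Homo sapiens) for inhibition, read by MTT assay, with a stated time of 48 h, tested at 10 uM; a higher number here means more inhibition at the concentration tested (going by the name of the read-out), a lower number less inhibition. Among them compound 2 gives the lowest number, 70.1%. Compound 1, at 82.5%, stands higher, a gap beyond the usual scatter, and compound 3 stands highest, at 90%, also beyond the scatter. Going by the values given here, with only three compounds, and no pair differing in a single place, no pattern can be read from these values.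

Compound 4, `O=C(Nc1cc(Nc2ccc(F)c(Cl)c2)ncn1)Nc1c(Cl)cccc1Cl`, has not yet been measured in this assay. It differs from compound 2 in one place: 3-chloro-4-fluorophenyl in place of 4-ethylphenyl on a nitrogen on an aromatic ring. The two groups that swap have the same count of heavy atoms and neither carries a hydrogen-bond donor or acceptor.

Among the compounds with values here, nothing among the measured compounds shows what this change does in this assay. A step of no size beyond the scatter, in either direction, is the expectation here, so the estimated step is a number 1.9 percentage points higher from compound 2 to compound 4 (within the scatter). Compound 4 is therefore expected to give about 72%, within a range from 50% to 90%.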

Compound 4, a percentage reported as inhibition, at one concentration (the size of the read-out at that concentration, not a potency): 91.1%
Beside the measured number, compound 4's estimate is 19.1 percentage points below it; measured number above the stated range.
By their numbers in this assay, from the lowest: compound 2; then compounds 1, 3 and 4 (each within the scatter of the next).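

In this assay, the aryl group on the anilino nitrogen proves able to move the read-out: putting 3-chloro-4-fluorophenyl in place of 4-ethylphenyl gives a number 21 percentage points higher from compound 2 to compound 4 (beyond the scatter). Going by these compounds alone, this is the first pair here that differs in one place, so a difference in the number can be tied to a single change rather than to several at once. The two groups have the same count of heavy atoms and neither carries a hydrogen-bond donor or acceptor, so those counts do not separate them, and no measurement here says why the change has this effect.

This single swap exchanges the ethyl group for two halogens at once, so it leaves open whether the chlorine, the fluorine or the loss of the ethyl group accounts for the step, and a plain phenyl ring or a ring carrying only one of the two halogens would begin to separate these. Also open, going by these compounds, is how this position responds to groups of another kind, such as an amine or a carboxylic acid on the ring, and whether the step would hold at concentrations other than the single one tested.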